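Compound 2 and a Larger Change at One End

A few compounds are considered here, and "the series" means these few. Any claim that something is new, unique, unknown or untested is made for them only; others in the source may bear on it.

Compound 1 (`COc1cc(NC(C)CCCNC(=O)NNC(=O)Nc2ccc(Cl)cc2)c2ncccc2c1`) reports only a limit of the assay at >= 250000 nM in a functional assay on MIA PaCa-2 cells (Homo sapiens) for inhibition, read by MTT assay, with a stated time of 72 h (on this read-out higher numbers stand for weaker inhibition and lower numbers for stronger inhibition), and gives no true number. Going by the values given here, compound 2 (`COc1cc(NC(C)CCCNC(=O)NNC(=O)Nc2cccc(Cl)c2)c2ncccc2c1`) gives 74000 nM in this assay and holds the only true number so far. Among the compounds with values here, the one measured step is an at least 3.3-fold lower number from compound 1 to compound 2 (0.52 log units; beyond the scatter) and it only exchanges 4-chlorophenyl for 3-chlorophenyl. That step rests on the limit of >= 250000 nM in this assay, at which 1 of the 2 values shown sits, and so fixes no exact size.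

Compound 3 (`COc1cc(NC(C)CCCNC(=O)Nc2ccc(O)cc2)c2ncccc2c1`) departs much further from compound 2, as 4-hydroxyphenyl in place of ((3-chlorophenyl)carbamoyl)amino on an amide-type nitrogen shows, with 4-hydroxyphenyl in place of ((3-chlorophenyl)carbamoyl)amino on an amide-type nitrogen. The small swap in an at least 3.3-fold lower number from compound 1 to compound 2 (0.52 log units; beyond the scatter) gives no direction for so large a replacement, so no step beyond the scatter is expected in this assay here. The expected step is a 1.5-fold lower number from compound 2 to compound 3 (0.17 log units; within the scatter) and it stays within that scatter. Compound 3 is estimated at 50000 nM with an expected range from 12000 nM to 200000 nM in this measurement.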

Compound 3, half-maximal inhibitory concentration: 57000 nM
Estimate against measurement, compound 3: 1.1-fold (0.06 log units) below, and the stated range covers the measured number.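

Replacing the whole ((3-chlorophenyl)carbamoyl)amino group with the smaller 4-hydroxyphenyl on this amide-type nitrogen gives a 1.3-fold lower number from compound 2 to compound 3 (0.11 log units; within the scatter) in this assay, so a far larger change than the chlorine swap leaves no difference that can be told from the scatter, and the ((3-chlorophenyl)carbamoyl)amino group is not needed to reach this level. Replacing ((4-chlorophenyl)carbamoyl)amino with the same 4-hydroxyphenyl gives an at least 4.3-fold lower number from compound 1 to compound 3 (0.64 log units; beyond the scatter), which shows that the position of the chlorine matters only within the longer group. The size of that second step stays open, as compound 1 provides a limit and not a true number: the limit of >= 250000 nM in this assay, at which 1 of the 3 values shown sits.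

On these data alone, whether an amine or a carboxylic acid in place of the hydroxy group of compound 3 would move the number beyond the scatter remains open. So does the effect of a longer carbon chain on the shared core.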